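The compounds below may be only part of what the source reports. "The series", "measured", "known", "first", "only" and "open" are said of these compounds alone.

Two compounds have been measured:
compound 1 `CSc1ccc(CNc2nc(SC)nc3ncccc23)cc1`
compound 2 `COc1ccc(CNc2nc(SC)nc3ncccc23)cc1`

In a functional assay on HTB-54 cells (Homo sapiens) for cytotoxicity, read by MTT assay, with a stated time of 72 h (a lower number here means a stronger inhibitor of growth, a higher number a weaker inhibitor of growth), compound 1 gives 3280 nM. For compound 2 the result is not a number but a limit of the assay, > 100000 nM. That result sits at the limit of > 100000 nM in this assay, at which 1 of the 2 values shown sits. Within the data shown here, compound 2 therefore stands at the weak end of what this assay can report, and the only measured step, an at least 30-fold higher number from compound 1 to compound 2 (1.48 log units; beyond the scatter), is a large loss.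

Compound 3 `CSc1nc(NCc2ccccc2)c2cccnc2n1` has not yet been measured. It differs from compound 2 by hydrogen in place of methoxy on an aromatic carbon. Among the measured compounds shown here, no measured step removes a group at this place; the step from compound 1 to compound 2 shows only that swapping one group for another at the same place, para to a large group, can move the number a great deal. A hydrogen is a third option there, so compound 3 is expected to land between the two measured outcomes, by an at least 3.3-fold lower number from compound 2 to compound 3 (0.52 log units; beyond the scatter), with wide uncertainty. Compound 3 is accordingly estimated at 30000 nM, in a range from 5000 nM to 150000 nM.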

Compound 3, concentration for 50% growth inhibition: 5080 nM
Compound 3: middle estimate off by 5.9-fold (0.77 log units), on the high side, within the range that was stated.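

Removing the methoxy group from the ring gives an at least 19-fold lower number from compound 2 to compound 3 (1.29 log units; beyond the scatter) in this assay, so the poor result of the earlier pair goes with the presence of methoxy at this place, not simply with the absence of methylsulfanyl. Hydrogen and methylsulfanyl cannot be told apart here, as the change between them is a 1.5-fold higher number from compound 1 to compound 3 (0.19 log units; within the scatter), which means that methylsulfanyl is not needed at this place for the growth inhibition seen with the shared core, and that of the three groups shown only methoxy stands apart. The result for compound 2 is a limit of the assay, not a number: the limit of > 100000 nM in this assay, at which 1 of the 3 values shown sits.

The compounds shown leave open whether methoxy is a special case or whether other groups para to a large group, such as an amine, a carboxylic acid or a longer chain like butoxy, would also give a weak result. They also cannot tell why methoxy differs so sharply from methylsulfanyl, or whether the same holds on other cell lines.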